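Aryl swap on the exocyclic alkene: cytotoxicity working notes

A few compounds are considered here, and "the series" means these few. Any claim that something is new, unique, unknown or untested is made for them only; others in the source may bear on it.

Compound 1 `CC(=O)OC[C@H]1O[C@@H](n2cc(CN3C(=O)/C(=C/c4ccc(N(C)C)cc4)c4ccccc43)nn2)[C@H](OC(C)=O)[C@@H](OC(C)=O)[C@@H]1OC(C)=O` gives 12700 nM in an ADME assay on NIH3T3 cells (Homo sapiens) for cytotoxicity, read by sulforhodamine B assay, with a stated time of 48 h; on this read-out higher numbers stand for weaker inhibition and lower numbers for stronger inhibition.
Compound 2 `CC(=O)OC[C@H]1O[C@@H](n2cc(CN3C(=O)/C(=C/c4ccc5ccccc5c4)c4ccccc43)nn2)[C@H](OC(C)=O)[C@@H](OC(C)=O)[C@@H]1OC(C)=O` gives 28400 nM in this assay.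

Compound 2 stands at the highest of the two numbers in this assay, with compound 1 nearest: a 2.2-fold higher number from compound 1 to compound 2 (0.35 log units; beyond the scatter). Compound 3 `CC(=O)OC[C@H]1O[C@@H](n2cc(CN3C(=O)/C(=C/c4cccs4)c4ccccc43)nn2)[C@H](OC(C)=O)[C@@H](OC(C)=O)[C@@H]1OC(C)=O` differs from compound 2 by thiophen-2-yl in place of naphthalen-2-yl on a double-bonded chain carbon bound to a double-bonded ring carbon. Going by the values given here, the only step at that carbon is a 2.2-fold higher number from compound 1 to compound 2 (0.35 log units; beyond the scatter), modest and beyond the scatter, so a further swap there is expected to move this assay by no more than a modest amount, direction uncertain. For compound 3 the estimate is 18000 nM (range 7000 nM to 45000 nM), meaning an expected 1.6-fold lower number from compound 2 to compound 3 (0.20 log units; within the scatter).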

Compound 3, half-maximal inhibitory concentration: 48100 nM
Estimate against measurement, compound 3: 2.7-fold (0.43 log units) below; measured number above the stated range.
By their numbers in this assay, from the lowest: compound 1; then compounds 2 and 3 (each within the scatter of the next).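

In this assay, the swap of naphthalen-2-yl for thiophen-2-yl gives a 1.7-fold higher number from compound 2 to compound 3 (0.23 log units; within the scatter), so these two groups are not separated despite their different ring systems. Replacing 4-(dimethylamino)phenyl with thiophen-2-yl gives a 3.8-fold higher number from compound 1 to compound 3 (0.58 log units; beyond the scatter), leaving compound 1 with the lowest number of the three, beyond the scatter from both others. Nothing available explains this difference.

Still open, as far as these compounds go, is whether the lower number of compound 1 depends on the dimethylamino group itself. A 4-aminophenyl, 4-methoxyphenyl or 4-carboxyphenyl group on the double-bonded chain carbon would test this.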